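Methyl on the Ring Nitrogen: Solubility Outlook for Compound 4

The compounds below may be only part of what the source reports. "The series", "measured", "known", "first", "only" and "open" are said of these compounds alone.

This account follows a small set of quinolinone-free descriptions is avoided; it simply follows three measured compounds and one still to be measured in a physicochemical assay for solubility; on this read-out lower numbers stand for lower solubility and higher numbers for higher solubility. Compound 3 `N#Cc1ccc(NCc2cc3cc(Cl)ccc3[nH]c2=O)c(=O)[nH]1` gives 2210 nM, the lower of the two numbers reported. Compound 2 `C[C@H](Nc1ccc(C#N)n(C)c1=O)c1cc2cc(Cl)c(OCc3ccccn3)cc2[nH]c1=O` gives 2500 nM, which lies within the scatter of the value for compound 3, so the two cannot be ordered. Compound 1 `Cn1c(C(F)(F)F)ccc(NCc2cc3cc(Cl)ccc3[nH]c2=O)c1=O` gives < 100 nM, which is a limit of this assay and not a number. Compound 4 `Cn1c(C#N)ccc(NCc2cc3cc(Cl)ccc3[nH]c2=O)c1=O` has not yet been measured; it differs from compound 3 by methyl in place of hydrogen on an aromatic nitrogen. Among the compounds with values here, no measured pair shows that single change on its own, so the size of the step is open. Compound 1, which also carries a methyl on that aromatic nitrogen, gives < 100 nM, a limit rather than a number. Taking that into view, compound 4 is expected to fall well beneath compound 3, with an estimated step of a 5.5-fold lower number from compound 3 to compound 4 (0.74 log units; beyond the scatter). The expected value for compound 4 is 400 nM, within a range from 80 nM to 2000 nM.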

Compound 4, solubility: 295 nM
Compound 4: middle estimate off by 1.4-fold (0.13 log units), on the high side; the range from low to high includes it.
By their numbers in this assay, from the lowest: compound 4; then compounds 3 and 2 (each within the scatter of the next). At a limit, below all of these: compound 1.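

In this assay, methyl in place of hydrogen on the aromatic nitrogen now has a size of its own, with the cyano group held fixed: a 7.5-fold lower number from compound 3 to compound 4 (0.87 log units; beyond the scatter). With that methyl kept, cyano in place of trifluoromethyl on the aromatic carbon gives an at least 2.9-fold higher number from compound 1 to compound 4 (0.46 log units; beyond the scatter), so the group on that carbon also moves the number, separately from the methyl. Compound 1 stands at a limit of the assay, and this second step is therefore a bound and not a full size: the limit of < 100 nM in this assay, at which 1 of the 4 values shown sits.

The compounds shown leave open whether the step from hydrogen to methyl keeps its size when trifluoromethyl stands in place of cyano. Also open, as far as these compounds go, is how an ethyl group or a longer chain on that nitrogen, or a carboxylic acid in place of cyano, would read in this assay.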